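Thioether side-chain change on the shared core

The source may report more compounds than this note shows. Statements on the series, on what has been measured and on what is new or still open speak of the compounds shown alone.

Measured so far:
compound 1 `O=c1cc(I)n([C@@H]2O[C@H](COP(=O)(O)OP(=O)(O)O)[C@@H](O)[C@H]2O)c(=O)[nH]1` gives 15 nM
compound 2 `O=C(O)CSc1ccn([C@@H]2O[C@H](COP(=O)(O)OP(=O)(O)O)[C@@H](O)[C@H]2O)c(=O)n1` gives 1700 nM
compound 3 `O=c1ccn([C@@H]2O[C@H](COP(=O)(O)OP(=O)(O)O)C[C@H]2O)c(=O)[nH]1` gives 2500 nM

All three numbers come from an in vitro functional assay on 1321-N1 cells for agonist activity at P2Y purinoceptor 6 (Homo sapiens); on this read-out higher numbers stand for an effect only at larger amounts of compound and lower numbers for an effect already at smaller amounts. Compound 2 stands second highest of the three numbers; its nearest neighbour is compound 3, whose number lies within the scatter of it, and its furthest is compound 1, whose number lies far below it, beyond the scatter. Compound 4 `CCSc1ccn([C@@H]2O[C@H](COP(=O)(O)OP(=O)(O)O)[C@@H](O)[C@H]2O)c(=O)n1` differs from compound 2 in one place: methyl in place of carboxy on a saturated chain carbon bound to a sulfur. For the measured compounds named here, no measured pair in this set shows that change, so its effect has no direct precedent here; the only information is that compound 1, built on the same core with a different substituent, sits far lower than compound 2 in this assay, while compound 3 sits close to it. Without a precedent, the step from compound 2 to compound 4 is expected to be small, a 1.1-fold lower number from compound 2 to compound 4 (0.05 log units; within the scatter), with no direction beyond the scatter claimed. Compound 4 is therefore estimated at 1500 nM, within a range from 300 nM to 7000 nM, the width reflecting the absence of any measured analogue for this change.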

Compound 4, half-maximal effective concentration: 280 nM
Beside the measured number, compound 4's estimate is 5.4-fold (0.73 log units) above it; the measured number lies below the stated range.
By their numbers in this assay, from the lowest: compound 1; then compound 4; then compounds 2 and 3 (each within the scatter of the next).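

In this assay, for the compounds shown here, the change of methyl in place of carboxy on a saturated chain carbon bound to a sulfur gives a 6.1-fold lower number from compound 2 to compound 4 (0.78 log units; beyond the scatter) and is the first one-place step readable. It shows that this position on the shared core is sensitive to what ends the thioether side chain, with ethylsulfanyl giving the lower number on this read-out than (carboxymethyl)sulfanyl. The data shown offer no measured property that would account for this step.

This single pair does not show whether the trend depends on removing the carboxy group or on introducing the methyl group. A longer chain such as propyl, a benzyl group or a terminal amine on the sulfur would show whether the number continues to fall, levels off or rises again.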